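Cyano for Methoxy on the Aryl Ring of Compound 1

This account rests on a few compounds, and the source may have more. Where it says the series, first, only, none or still open, it means among the compounds named here.

Compound 1 `COc1cccc(-c2cc(C)c3ncc(CSCCc4ccccc4)n3c2)c1` was tested in an ADME assay on HEL cells (Homo sapiens) for cytotoxicity, with a stated time of 3 days (a lower number here means that less compound is tolerated, a higher number that more compound is tolerated), where compound 1 gives 20 ug/mL. Of the three numbers recorded, this is the lowest. Compound 2 `Cc1cc(-c2ccsc2)c2ncc(CSCCc3ccccc3)n2c1` gives 100 ug/mL in this assay, and compound 3 `COc1cccc(-c2cc(C)cn3c(CSCCc4ccccc4)cnc23)c1` gives 100 ug/mL; both stand above compound 1 by a margin beyond the scatter. Among the measured compounds shown here, the only one-place step among the measured compounds, no change at the digits printed from compound 2 to compound 3 (within the scatter), swaps one aryl group for another without moving the number. Compound 4 `Cc1cc(-c2cccc(C#N)c2)cn2c(CSCCc3ccccc3)cnc12` differs from compound 1 by cyano in place of methoxy on an aromatic carbon. For the measured compounds named here, no measured step exchanges these two groups, so the expectation rests on the position of compound 1 alone and on the observation that the aryl swap of the known step left the read-out unchanged. He therefore expects at most a small step, a 1.5-fold higher number from compound 1 to compound 4 (0.18 log units; within the scatter), toward the level of compound 2 and compound 3, with no strong reason to predict movement beyond the scatter. His estimate for compound 4 is 30 ug/mL, within a range from 10 ug/mL to 100 ug/mL.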

Compound 4, minimum cytotoxic concentration: > 100 ug/mL
Compound 4 was reported as a limit (the forecaster's own chance of this, stated with the estimate: 20%); at least 3.3-fold (0.52 log units) between middle value and limit.
By their numbers in this assay, from the lowest: compound 1; then compounds 2 and 3 (each within the scatter of the next).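

In this assay, the exchange of methoxy for cyano on this aryl ring is the first one-place change shown to move the read-out beyond the scatter, with an at least 5.0-fold higher number from compound 1 to compound 4 (0.69 log units; beyond the scatter). Among the compounds shown here, the only earlier step, with no change at the digits printed from compound 2 to compound 3 (within the scatter), exchanged one aryl group for another at a different carbon of the core and left the read-out where it was, so the small substituent on the aryl ring of compound 1 matters in a way that step could not reveal. For compound 4 the value is a limit of the assay and not a number: the limit of > 100 ug/mL in this assay, at which 1 of the 4 values shown sits.

On these data alone, whether a plain phenyl ring, or an amine or a carboxylic acid in the same place, would read like compound 1 or like compound 4 stays open. Also open, as far as these compounds go, is whether cyano in place of methoxy would move compound 3 at all.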